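The source may report more compounds than this note shows. Statements on the series, on what has been measured and on what is new or still open speak of the compounds shown alone.

Measured in a functional assay on HeLa cells (Homo sapiens) for inhibition, read by CCK-8 assay, with a stated time of 48 h; a higher number here means a weaker inhibitor of growth, a lower number a stronger inhibitor of growth:
- compound 1 `O=C(CCCSC[C@H](NC(=O)OCc1ccccc1)C(=O)Nc1ccccc1)NO`: 3800 nM
- compound 2 `O=C(CCCSC[C@H](NC(=O)OCc1ccccc1)C(=O)Nc1cccc2ccccc12)NO`: 4300 nM

For the measured compounds named here, compound 1 has only one measured neighbour, and the two values lie within the scatter of each other, so the numbers set no order between them. The account now turns from compound 1 to compound 3 `O=C(CCCSC[C@H](NC(=O)c1ccccc1)C(=O)Nc1ccccc1)NO`. The structural change is phenyl in place of benzyloxy on a carbonyl carbon. Cut one bond further out, it reads benzyloxycarbonyl to benzoyl.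

Going by the values given here, only one measured step is available: a 1.1-fold higher number from compound 1 to compound 2 (0.05 log units; within the scatter). That step concerns naphthalen-1-yl in place of phenyl on an amide-type nitrogen, so it lies elsewhere in the molecule and bears on the new change only indirectly. Among the compounds with values here, no measured compound varies the group on the carbonyl carbon, so the data give no firm direction. In this assay, no step beyond the scatter is therefore expected, though this rests on thin evidence. The estimated step is a 1.2-fold higher number from compound 1 to compound 3 (0.07 log units; within the scatter). For compound 3 the expected value is 4500 nM, with an estimated range from 1800 nM to 11000 nM.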

Compound 3, concentration for 50% growth inhibition: 4100 nM
Beside the measured number, compound 3's estimate is 1.1-fold (0.04 log units) above it, within the range that was stated.
By their numbers in this assay, from the lowest: compounds 1, 3 and 2 (each within the scatter of the next).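

For the compounds shown here, for the first time the group on this carbonyl carbon is varied in this assay, and phenyl in place of benzyloxy gives a 1.1-fold higher number from compound 1 to compound 3 (0.03 log units; within the scatter) so the numbers set no order between the two groups. Benzyloxy, with 8 heavy atoms and 1 hydrogen-bond acceptor, and phenyl, with 6 heavy atoms and 0 hydrogen-bond acceptors, both carry one six-membered aromatic ring of carbon only, and in this read-out the difference between them does not show beyond the scatter. No measurement is available that would account for this result.

The compounds shown place only these two ring-bearing groups on this carbonyl carbon, so it remains open whether a group without such a ring, such as methyl, an aminomethyl group or a chain ending in a carboxylic acid, would also stay within the scatter of compound 1 or would depart from it. Going by these compounds, it also remains open whether phenyl on this carbonyl carbon and naphthalen-1-yl on the amide-type nitrogen, taken together in one compound, would give a number in the same range.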